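Swapping a saturated ether for a pyridine on piperazine

The source may hold more compounds than are shown below. What is called first, only, known or untested is meant among the compounds shown, and "the series" means these compounds.

Measured compounds:
- compound 1 `CCCCN1CCN(CCC(=O)Nc2nc3c(C)cccc3s2)CC1`: no result reported
- compound 2 `Cc1cccc2sc(NC(=O)CCN3CCN(CCCN(C)C)CC3)nc12`: 18100 nM
- compound 3 `Cc1cccc2sc(NC(=O)CCN3CCN(CC4CCCO4)CC3)nc12`: no result reported

All three share one amide-linked core and differ only in the group attached to the piperazine nitrogen. In an assay on HEK293 cells for antagonist activity at P2X purinoceptor 7 (Homo sapiens), read by fluorescence, with stated times of 30 min and 120 min (a lower number here means a stronger inhibitor, a higher number a weaker inhibitor), compound 2 gives 18100 nM, a weak result. Within the data shown here, compound 3 stands without a single number in this assay, and compound 1 is likewise without one, so the series offers only one measured point and no step between measured compounds from which a trend could be read.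

Compound 4 `Cc1cccc2sc(NC(=O)CCN3CCN(c4ccccn4)CC3)nc12` arises from compound 3 by one change: pyridin-2-yl in place of (oxolan-2-yl)methyl on an amine nitrogen in a ring. Among the measured compounds shown here, with no measured step to lean on, the expectation for this assay is a change of no clear direction and not beyond the usual scatter relative to the one known value. Compound 4 is therefore expected to be a weak inhibitor, around 15000 nM, plausibly anywhere between 4000 nM and 60000 nM, with a fair chance that only a limit is reported.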

Compound 4, half-maximal inhibitory concentration: 1400 nM
Beside the measured number, compound 4's estimate is 11-fold (1.03 log units) above it, and the stated range ends above it.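

In this assay, the group on the piperazine nitrogen can move the result well beyond the usual scatter: pyridin-2-yl in place of 3-(dimethylamino)propyl gives a 13-fold lower number from compound 2 to compound 4 (1.11 log units; beyond the scatter). Among these compounds, this is the first measured step, and it shows that this position is not indifferent to what it carries, with the aromatic ring giving the lower number of the two. Steps involving compound 1 and compound 3 cannot be read, and no measurement at hand gives a reason for the gain.

The compounds shown leave open whether the gain needs the ring nitrogen of pyridin-2-yl at all, which plain phenyl on the same piperazine nitrogen would test, and whether pyridin-3-yl would serve as well. They also leave open whether the aromatic ring must sit directly on that nitrogen, a question benzyl would address.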